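Compound 4, the Mirror Image of Compound 3

The source may report more compounds than this note shows. Statements on the series, on what has been measured and on what is new or still open speak of the compounds shown alone.

In a functional assay on MCF7 cells (Homo sapiens) for antiproliferative activity, with a stated time of 48 h (a higher number here means a weaker inhibitor, a lower number a stronger inhibitor), compound 1 (`Cc1cc(=O)c2c(OCC3CO3)cc(OCC3CO3)cc2o1`), drawn without configuration at its two stereocentres, gives 6500 nM. Compound 2 (`Cc1cc(=O)c2c(OC[C@H]3CO3)cc(OC[C@H]3CO3)cc2o1`) gives 220000 nM, and compound 3 (`Cc1cc(=O)c2c(OC[C@@H]3CO3)cc(OC[C@H]3CO3)cc2o1`) gives 13900 nM, the second highest of the three numbers. Compound 4 (`Cc1cc(=O)c2c(OC[C@H]3CO3)cc(OC[C@@H]3CO3)cc2o1`) is the mirror image of compound 3: the two compounds have the same atoms and bonds and differ only in configuration as drawn: 2 of 2 stereo elements differ (all stereocentres are inverted: mirror images); a stereocentre at a saturated ring carbon is drawn S in compound 3 and R in compound 4; a stereocentre at a saturated ring carbon is drawn R in compound 3 and S in compound 4. Inverting a single stereocentre gave a 16-fold lower number from compound 2 to compound 3 (1.20 log units; beyond the scatter), so configuration alone can matter greatly here. The undefined material has the lowest number, with a 34-fold higher number from compound 1 to compound 2 (1.53 log units; beyond the scatter) and a 2.1-fold higher number from compound 1 to compound 3 (0.33 log units; beyond the scatter), which suggests that a form not yet measured may be stronger than both defined ones. A modest drop is therefore expected, with a 2.3-fold lower number from compound 3 to compound 4 (0.36 log units; beyond the scatter). Compound 4 is estimated at 6000 nM, within a range of 1500 nM to 30000 nM.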

Compound 4, half-maximal inhibitory concentration: 1880 nM
Beside the measured number, compound 4's estimate is 3.2-fold (0.50 log units) above it; measured number inside the range.
By their numbers in this assay, from the lowest: compound 4; then compound 1; then compound 3; then compound 2.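

In this assay the two mirror images do not read alike (a 7.4-fold lower number from compound 3 to compound 4 (0.87 log units; beyond the scatter)), so the full inversion of both stereocentres matters here and not only the single inversions seen before. Among the compounds with a defined configuration, only compound 4 stands below the undefined compound 1 (a 3.5-fold lower number from compound 1 to compound 4 (0.54 log units; beyond the scatter)). A single inversion starting from compound 2 also reaches further in this direction (a 120-fold lower number from compound 2 to compound 4 (2.07 log units; beyond the scatter)) than the inversion of the other stereocentre did (a 16-fold lower number from compound 2 to compound 3 (1.20 log units; beyond the scatter)).

From the compounds shown here alone, all four compounds share the same atoms and bonds, so what an amine or a carboxylic acid in place of either side chain would do stays open. Going by these compounds, whether compound 4 is present in the undefined compound 1 also stays open.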